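The source may report more compounds than this note shows. Statements on the series, on what has been measured and on what is new or still open speak of the compounds shown alone.

Compounds in this small set share one core and differ in the group on an oxygen on an aromatic ring. In a physicochemical assay for solubility, with a stated time of 3 days, at pH 2 (on this read-out lower numbers stand for lower solubility and higher numbers for higher solubility), compound 1 `NC(=O)c1ccc2[nH]c(-c3ccc(OCCCO)cc3)nc2c1` gives 185000 nM. Compound 2 `CN1CCC(Oc2ccc(-c3nc4cc(C(N)=O)ccc4[nH]3)cc2)CC1` gives > 400000 nM, which is a limit of the assay and not a number. Compound 3 `NC(=O)c1ccc2[nH]c(-c3ccc(OCC4CCCNC4)cc3)nc2c1` has no place on this scale, since its entry reads "not determined" (no result reported).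

The move to compound 4 `NC(=O)c1ccc2[nH]c(-c3ccc(OCC4CCNCC4)cc3)nc2c1` is a small one: piperidin-4-yl in place of piperidin-3-yl on a saturated chain carbon bound to an oxygen on an aromatic ring. Here piperidin-4-yl stands in place of piperidin-3-yl on a saturated chain carbon bound to an oxygen on an aromatic ring, so the two compounds have the same atoms, joined differently.

Among the measured compounds shown here, no measured step tests this swap directly. For the measured compounds named here, the only one is a different change, 1-methylpiperidin-4-yl in place of 3-hydroxypropyl, and it gives an at least 2.1-fold higher number from compound 1 to compound 2 (0.33 log units; beyond the scatter). With no number for compound 3, no measured change can be applied to it, and no step beyond the scatter is expected from the swap itself. Given that one measured step, an at least 2.1-fold higher number from compound 1 to compound 2 (0.33 log units; beyond the scatter), compound 4 is expected to lie nearer compound 2 than compound 1, at the high end of the scale. The estimate for compound 4 is 330000 nM, with an expected range from 160000 nM to 400000 nM.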

Compound 4, solubility: > 400000 nM
Compound 4 ended at the assay's limit (the forecaster's own chance of this, stated with the estimate: 50%); middle value at least 1.2-fold (0.08 log units) from the limit.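

In this assay, the change to the (piperidin-4-yl)methyl group gives an at least 2.1-fold higher number from compound 1 to compound 4 (0.33 log units; beyond the scatter), so a second piperidine side chain, one with a free ring nitrogen and no methyl group on it, also moves the number up from the hydroxyl-bearing chain. Among the compounds with a result, the two carrying a piperidine ring, compound 2 and compound 4, both end at a limit of the assay and not at a number, while compound 1 lies lower; compound 3 has no number, so it neither supports nor opposes this pattern. The step from compound 2 to compound 4 cannot be read, as both sit at the same ceiling: the limit of > 400000 nM in this assay, at which 2 of the 4 values shown sit.

On these data alone, the swap from piperidin-3-yl to piperidin-4-yl remains untested, with no number for compound 3 to compare. An open-chain amine such as 3-aminopropyl, or a carboxylic acid, on the same oxygen would show whether the piperidine ring itself is needed to reach this limit, or whether other groups on the chain do the same.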